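The compounds below may be only part of what the source reports. "The series", "measured", "known", "first", "only" and "open" are said of these compounds alone.

Compound 1, `Cc1cc(=O)[nH]c2cc(NC(=O)c3cccc4ccccc34)ccc12`: in a physicochemical assay for lipophilicity (a lower number here means a more polar compound, a higher number a more lipophilic compound), compound 1 gives 1.72.
Compound 2, `Cc1ccc(C(=O)Nc2ccc3c(C)cc(=O)[nH]c3c2)cc1`: compound 2 gives 1.67.
Compound 3, `Cc1cc(O)nc2cc(N)ccc12`: compound 3 gives 0.793.

Among these three numbers compound 2 holds the second highest place. Compound 1 sits nearest, within the usual scatter, so the two cannot be ranked against each other. Compound 3 lies far lower, beyond the scatter. Compound 4, `Cc1cc(=O)[nH]c2cc(NC(=O)c3ccccc3)ccc12`, has not yet been measured. It differs from compound 2 in one place: hydrogen in place of methyl on an aromatic carbon. The methyl, a single carbon, leaves and a hydrogen atom enters. Within the data shown here, none of the measured pairs shows this change, so the expectation rests on the change alone. A modest fall in this assay, somewhat beyond the scatter, is expected. Compound 4 is therefore estimated at 1.2, between 0.85 and 1.55, a step of a number 0.47 log units lower from compound 2 to compound 4 (beyond the scatter).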

Compound 4, partition coefficient: 1.66
The estimate for compound 4 lay 0.46 log units below the measured number; the measured number lies above the stated range.
By their numbers in this assay, from the lowest: compound 3; then compounds 4, 2 and 1 (each within the scatter of the next).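

Within this assay, the change from 4-methylphenyl to phenyl gives a step of a number 0.01 log units lower from compound 2 to compound 4 (within the scatter). On this aromatic carbon, para to a large group, this first measured pair therefore cannot be told apart by this read-out. Nothing measured here accounts for this result.

One pair covers only methyl and hydrogen at this position. On these data alone, whether an amine, a carboxylic acid or a longer chain on the same carbon would give a step beyond the scatter remains open.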